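The compounds below may be only part of what the source reports. "The series", "measured", "known", "first", "only" and "open" are said of these compounds alone.

In a functional assay on A2780 cells (Homo sapiens) for antiproliferative activity, read by fluorescence, with a stated time of 72 h (on this read-out lower numbers stand for stronger inhibition and higher numbers for weaker inhibition), compound 1 `CC(=O)N1CCN(C(=O)N2Cc3c(NC(=O)c4ccc(F)cc4)n[nH]c3C2(C)C)CC1` reads > 10000 nM, which is a limit of the assay and not a number. Compound 2 `CC(C)(C)C(=O)N1Cc2c(NC(=O)c3cccnc3)n[nH]c2C1(C)C` gives 690 nM and compound 3 `CC1(C)c2[nH]nc(NC(=O)c3ccc(F)cc3)c2CN1C(=O)C1CCN(C2CC2)CC1` gives 380 nM, two values within the scatter of each other. Compound 4 `CC(C)(C)C(=O)N1Cc2c(NC(=O)c3ccc(F)cc3)n[nH]c2C1(C)C` has tert-butyl in place of the 1-cyclopropylpiperidin-4-yl of compound 3, on a carbonyl carbon: tert-butyl in place of 1-cyclopropylpiperidin-4-yl on a carbonyl carbon. For the measured compounds named here, the only measured step at this place, an at least 26-fold lower number from compound 1 to compound 3 (1.42 log units; beyond the scatter), is large, but it starts from a limit and involves a different group. Compound 2 also carries tert-butyl at this place and gives 690 nM, so no step beyond the scatter is expected in this assay. The expected step is a 1.2-fold higher number from compound 3 to compound 4 (0.07 log units; within the scatter). For compound 4 the estimated value is 450 nM, with an expected range of 130 nM to 1500 nM.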

Compound 4, half-maximal inhibitory concentration: 270 nM
Estimate against measurement, compound 4: 1.7-fold (0.22 log units) above, within the range that was stated.
By their numbers in this assay, from the lowest: compounds 4, 3 and 2 (each within the scatter of the next, the first and the last beyond it). At a limit, above all of these: compound 1.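

In this assay, the swap at this carbonyl carbon shows a 1.4-fold lower number from compound 3 to compound 4 (0.15 log units; within the scatter), so the read-out does not depend on the rings or the nitrogen of 1-cyclopropylpiperidin-4-yl. With tert-butyl held fixed, the other carbonyl substituent can now be read, with 4-fluorophenyl in place of pyridin-3-yl giving a 2.6-fold lower number from compound 2 to compound 4 (0.41 log units; beyond the scatter). The third step, an at least 37-fold lower number from compound 1 to compound 4 (1.56 log units; beyond the scatter), starts from a limit of the assay and gives no exact size.

As far as these compounds go, how a primary amine or a carboxylic acid would read at this place stays open. From the compounds shown here alone, it is also open whether the preference for 4-fluorophenyl over pyridin-3-yl holds with 1-cyclopropylpiperidin-4-yl in place of tert-butyl.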